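A few compounds are considered here, and "the series" means these few. Any claim that something is new, unique, unknown or untested is made for them only; others in the source may bear on it.

Measured in a functional assay on NCI-H1993 cells (Homo sapiens) for inhibition, read by CCK-8 assay, with a stated time of 72 h (a higher number here means a weaker inhibitor, a lower number a stronger inhibitor), are these:
compound 1 `CC(c1c(F)cc2ncccc2c1F)n1cnc2ncc(-c3cnn(C)c3)nc21` gives 35.5 nM
compound 2 `CC(c1cc2cccnc2cc1F)n1cnc2ncc(-c3cnn(CCO)c3)nc21` gives 175 nM

Compound 2 stands higher of the two, and its gap to compound 1 lies beyond the scatter. Compound 3 `CC(c1c(F)cc2ncccc2c1F)n1cnc2ncc(-c3cnn(CCO)c3)nc21` comes from compound 2 by one change (fluoro in place of hydrogen on an aromatic carbon), fluoro in place of hydrogen on an aromatic carbon. This matches the fluoro pattern of compound 1 (35.5 nM), but compound 1 also differs elsewhere, so only part of the gap is expected to follow. An estimated 2.5-fold lower number from compound 2 to compound 3 (0.40 log units; beyond the scatter) is expected, a drop beyond the scatter. For compound 3 the expected value is 70 nM (estimated range 25 nM to 190 nM).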

Compound 3, half-maximal inhibitory concentration: 83.7 nM
Compound 3: middle estimate off by 1.2-fold (0.08 log units), on the low side, within the range that was stated.
By their numbers in this assay, from the lowest: compound 1; then compound 3; then compound 2.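

In this assay, the added fluoro on the aromatic carbon ortho to a fused ring brings a modest gain of its own, a 2.1-fold lower number from compound 2 to compound 3 (0.32 log units; beyond the scatter). With that fluoro pattern held fixed, hydroxymethyl in place of hydrogen on the saturated chain carbon bound to an aromatic nitrogen gives a modest loss, a 2.4-fold higher number from compound 1 to compound 3 (0.37 log units; beyond the scatter), so two separate steps now make up the gap between compound 1 and compound 2. Nothing given here offers a reason for either step. As far as these compounds go, whether an amine or a longer chain in place of the hydroxymethyl would stand nearer to compound 1 remains open.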